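This account rests on a few compounds, and the source may have more. Where it says the series, first, only, none or still open, it means among the compounds named here.

Compound 1 `O=C(CSc1nc2ccc(NC(=O)c3ccc([N+](=O)[O-])cc3)cc2s1)NCc1ccccc1`: > 100000 nM
Compound 2 `COc1ccc(CNC(=O)CSc2nc3ccc(NC(=O)c4ccccc4)cc3s2)cc1`: 12700 nM
Compound 3 `COc1ccc(CNC(=O)CSc2nc3ccc(NC(=O)c4ccc([N+](=O)[O-])cc4)cc3s2)cc1`: > 100000 nM

Of the compounds shown here, three built on one shared core have been tested in a functional assay on HepG2 cells (Homo sapiens) for cytotoxicity, read by MTT assay, with a stated time of 48 h; a lower number here means a stronger inhibitor, a higher number a weaker inhibitor. Compound 2 gives 12700 nM there. Compound 3 gives only a limit, > 100000 nM, and its number is not known. Compound 1 sits at a limit as well, > 100000 nM. Among the compounds with values here, compound 3 thus stands together with compound 1 at the limit of > 100000 nM in this assay, at which 2 of the 3 values shown sit, while compound 2 is the one compound with a read number.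

Two measured steps lead into compound 3. The step of an at least 7.8-fold higher number from compound 2 to compound 3 (0.89 log units; beyond the scatter) is clear in direction. The step that the two limits leave unreadable from compound 1 to compound 3 tells nothing about size.

Compound 4 `CNC(=O)CSc1nc2ccc(NC(=O)c3ccc([N+](=O)[O-])cc3)cc2s1` has not yet been measured. Its difference from compound 3 is hydrogen in place of 4-methoxyphenyl on a saturated chain carbon bound to an amide-type nitrogen; cut one bond further out, this reads 4-methoxybenzyl to methyl. Neither measured step makes this change. The nearest is the methoxy step from compound 1 to compound 3, which stays unreadable. Since compound 1 and compound 3 both sit at the limit of > 100000 nM in this assay, at which 2 of the 3 values shown sit, no step beyond the scatter is expected here. The expected step is a step that the limit leaves unreadable from compound 3 to compound 4. Compound 4 is expected to give about 150000 nM, most likely again only as a limit, within 50000 nM to 500000 nM.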

Compound 4, half-maximal inhibitory concentration: > 100000 nM
Compound 4 ended at the assay's limit; the forecaster's own chance of this, stated with the estimate: 85%; the middle value is on the limit's open side.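

Compound 4 gives > 100000 nM, which is a limit of the assay and not a number. No new step can be read, as the steps linking compound 4 to compound 3 and to compound 1 join limit to limit: the limit of > 100000 nM in this assay, at which 3 of the 4 values shown sit.

The compounds shown leave open whether 4-methoxybenzyl to methyl changes anything in this assay; only compound 2 carries a read number.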